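The source may hold more compounds than are shown below. What is called first, only, known or untested is meant among the compounds shown, and "the series" means these compounds.

Working notes on the series. Within the data shown here, the core shared by compound 1 `COC[C@H](NC1CCN(CCCc2c[nH]c3ccc(Cn4cncn4)cc23)CC1)c1ccc(F)cc1` and compound 3 `OC[C@H](NC1CCN(CCCc2c[nH]c3ccc(Cn4cncn4)cc23)CC1)c1ccccc1` differs from that of compound 2 `CC(C)=CCCN(C)C1CCN(CCCc2c[nH]c3ccc(-n4cnnc4)cc23)CC1` in the five-membered heteroaromatic attachment, so no single step joins compound 2 to either. In an assay on CHO cells for displacement of a labelled ligand from 5-hydroxytryptamine receptor 1B (Homo sapiens) (a lower number here means a stronger inhibitor, a higher number a weaker inhibitor), compound 2 gives 24 nM, the lowest of the three numbers shown; compound 1 gives 1200 nM and compound 3 gives 1300 nM, both far beyond the scatter from compound 2. Among the measured compounds shown here, the only measured step, a 1.1-fold higher number from compound 1 to compound 3 (0.03 log units; within the scatter), concerns a swap of two substituents on an amine nitrogen and lies within the scatter; it does not share the change now at hand.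

Compound 4 `c1cc(CNC2CCN(CCCc3c[nH]c4ccc(-n5cnnc5)cc34)CC2)co1` is not yet measured. It differs from compound 2 by ((furan-3-yl)methyl)amino in place of methyl(4-methylpent-3-en-1-yl)amino on a saturated ring carbon. Nothing measured tracks this exchange, so the expectation rests on the gap between compound 2 and the secondary-amine pair, compounds 1 and 3. A loss is expected, a 5.0-fold higher number from compound 2 to compound 4 (0.70 log units; beyond the scatter), of moderate size. Compound 4 is estimated at 120 nM, within 30 nM to 500 nM.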

Compound 4, half-maximal inhibitory concentration: 78 nM
For compound 4 the middle estimate is 1.5-fold (0.19 log units) above the measured one, and the stated range covers the measured number.
By their numbers in this assay, from the lowest: compound 2; then compound 4; then compounds 1 and 3 (each within the scatter of the next).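

On the saturated ring carbon of the core of compound 2, this assay shows that ((furan-3-yl)methyl)amino in place of methyl(4-methylpent-3-en-1-yl)amino costs only a 3.3-fold higher number from compound 2 to compound 4 (0.51 log units; beyond the scatter), a modest loss beyond the scatter. Among these compounds, this is the first reading of this exchange on this core, and it shows that neither the open chain nor its double bond is required for a number of this order. One step changes the chain, the ring and the hydrogen-bond donor together, and no measurement available explains the loss.

Still open, as far as these compounds go, is whether the loss tracks the hydrogen-bond donor on the amine nitrogen or the furan ring itself. A methyl group on that nitrogen, or benzylamino in place of the furan-bearing group, would separate the two.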